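The source may report more compounds than this note shows. Statements on the series, on what has been measured and on what is new or still open speak of the compounds shown alone.

Measured so far in a functional assay on MDA-MB-231 cells (Homo sapiens) for inhibition, read by sulforhodamine B assay, with a stated time of 48 h; on this read-out lower numbers stand for higher toxicity in this test and higher numbers for lower toxicity in this test:
compound 1 `COc1cc(-c2nn(-c3cccc(NC(=O)c4ccc(Cl)c(C(F)(F)F)c4)c3)cc2-c2ccncc2)ccc1Cl`: > 32500 nM
compound 2 `COc1cc(-c2nn(-c3cccc(NC(=O)Nc4ccc(Cl)c(C(F)(F)F)c4)c3)cc2-c2ccncc2)ccc1Cl`: 13300 nM

The value of compound 1 is a limit of this assay, not a number (the limit of > 32500 nM in this assay, at which 1 of the 2 values shown sits). Compound 2 holds the only number shown. Within the data shown here, the one step measured, an at least 2.4-fold lower number from compound 1 to compound 2 (0.38 log units; beyond the scatter), concerns the carbonyl, not the methoxy.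

Compound 3 `O=C(Nc1cccc(-n2cc(-c3ccncc3)c(-c3ccc(Cl)c(O)c3)n2)c1)Nc1ccc(Cl)c(C(F)(F)F)c1` differs from compound 2 by hydrogen in place of methyl on an oxygen on an aromatic ring. Among the measured compounds shown here, no measured step bears on this change, so no step beyond the scatter is expected in this assay; the estimate is a 1.1-fold higher number from compound 2 to compound 3 (0.02 log units; within the scatter). For compound 3 the expected value is 14000 nM, within 6000 nM to 32000 nM.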

Compound 3, concentration lethal to 50% of the cells: 11400 nM
Estimate against measurement, compound 3: 1.2-fold (0.09 log units) above; low and high end bracket the measured number.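

Methoxy to hydroxy on the 4-chloro-3-methoxyphenyl ring gives in this assay a 1.2-fold lower number from compound 2 to compound 3 (0.07 log units; within the scatter). At this oxygen, methyl and hydrogen are therefore not told apart by this read-out, whereas the earlier step concerned the carbonyl and said nothing about this position. Nothing measured here offers a reason for this result.

Still open, from the compounds shown here alone, is what an ethyl group or a longer chain on this oxygen, or an amine in place of the hydroxy, would do to the value. Also open, going by these compounds, is whether the same change would read alike in compound 1, whose value is a limit.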